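The compounds below may be only part of what the source reports. "The series", "measured", "known", "first", "only" and "open" are said of these compounds alone.

Measured so far:

- compound 1, `CN(C)C(=O)c1cc2cnc(Nc3ccc(S(=O)(=O)NCCCCCCN=C=S)cc3)nc2n1C1CCCC1`: 101%
- compound 2, `CN(C)C(=O)c1cc2cnc(Nc3ccc(S(=O)(=O)NCCCCCCCN=C=S)cc3)nc2n1C1CCCC1`: 101%
- compound 3, `CN(C)C(=O)c1cc2cnc(Nc3ccc(C(=O)NCCCCCCN=C=S)cc3)nc2n1C1CCCC1`: 100%

All three were read in a functional assay on A549 cells (Homo sapiens) for inhibition, read by CCK-8 assay, with a stated time of 72 h, tested at 10 uM; on this read-out lower numbers stand for a weaker effect and higher numbers for a stronger effect at the one concentration tested. From compound 1 to compound 2 the change is a group of 4 heavy atoms (2 carbon, 1 nitrogen, 1 sulfur; no ring) in place of a group of 3 heavy atoms (1 carbon, 1 nitrogen, 1 sulfur; no ring), on a saturated chain carbon, six bonds along the chain from a sulfonamide nitrogen; the step is no change at the digits printed from compound 1 to compound 2 (within the scatter). Compound 3 carries a core that differs from that of compound 1, and the difference between the two cores is not broken down here; its value in this assay sits within the scatter of compound 1 and compound 2.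

Compound 4, `CN(C)C(=O)c1cc2cnc(Nc3ccc(C(=O)NCCCCCCCN=C=S)cc3)nc2n1C1CCCC1`, differs from compound 3 by a group of 4 heavy atoms (2 carbon, 1 nitrogen, 1 sulfur; no ring) in place of a group of 3 heavy atoms (1 carbon, 1 nitrogen, 1 sulfur; no ring), on a saturated chain carbon, six bonds along the chain from an amide-type nitrogen. For the measured compounds named here, this is the same kind of change as the one from compound 1 to compound 2, not the same one: there the place was six bonds along the chain from a sulfonamide nitrogen, here it is six bonds along the chain from an amide-type nitrogen. Because the earlier step was no change at the digits printed from compound 1 to compound 2 (within the scatter), the step from compound 3 to compound 4 is expected to be no change at the digits printed from compound 3 to compound 4 (within the scatter). Compound 4 is expected to give 100% in this assay, estimated between 92% and 102%.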

Compound 4, a percentage reported as inhibition, at one concentration (the size of the read-out at that concentration, not a potency): 101%
Estimate against measurement, compound 4: 1 percentage points below; the measured number falls inside the stated range.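

In this assay, putting the group of 4 heavy atoms in place of the group of 3 heavy atoms on the core of compound 3 gives a number 1 percentage points higher from compound 3 to compound 4 (within the scatter). The same change reads alike on the two cores: the same change on two cores in this assay, no change at the digits printed (within the scatter) from compound 1 to compound 2 and a number 1 percentage points higher (within the scatter) from compound 3 to compound 4, 1 percentage points apart, within the scatter of two such steps. This shows that the change carries from one core to the other at the one concentration tested, but the read-out is not a potency, so it does not show whether the two cores would still agree at lower concentrations.

Still open, as far as these compounds go, is whether a much shorter chain or a much longer chain would read differently in this assay. The same holds for an amine or a carboxylic acid in place of the sulfur-bearing group.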